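The compounds below may be only part of what the source reports. "The series", "measured", "known", "first", "only" and "open" are said of these compounds alone.

Measured compounds in a functional assay on U-937 cells (Homo sapiens) for antiproliferative activity, read by CCK-8 assay, with a stated time of 24 h; on this read-out higher numbers stand for weaker inhibition and lower numbers for stronger inhibition:
compound 1 `Cc1ccc(NC(=O)c2ccc(CN3CCCN(C)CC3)cc2)cc1-n1cc(-c2cnc3ccnn3c2)cn1` gives 6830 nM
compound 3 `COc1ccc(C(=O)Nc2ccc(C)c(-n3cc(-c4cnc5ccnn5c4)cn3)c2)cc1` gives 16300 nM
compound 2 `Cc1ccc(NC(=O)c2ccc(C(F)(F)F)cc2)cc1-n1cc(-c2cnc3cccnn23)cn1` gives > 20000 nM, which is a limit of the assay and not a number.

Compound 3 stands at the highest of the two numbers in this assay. Within the data shown here, its nearest neighbour is compound 1, and the single one-point step measured so far runs a 2.4-fold higher number from compound 1 to compound 3 (0.38 log units; beyond the scatter), a modest weakening. Among the measured compounds shown here, compound 2 sits at a limit only the limit of > 20000 nM in this assay, at which 1 of the 3 values shown sits, and carries a different core, so it gives no step.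

Compound 4 `Cc1ccc(NC(=O)c2ccc(C(F)(F)F)cc2)cc1-n1cc(-c2cnc3ccnn3c2)cn1` differs from compound 3 in one place: trifluoromethyl in place of methoxy on an aromatic carbon. For the measured compounds named here, no measured step covers this exchange on the shared core. Going by the values given here, the only measured step, a 2.4-fold higher number from compound 1 to compound 3 (0.38 log units; beyond the scatter), concerns another exchange at that aromatic carbon and points the same way, toward weaker inhibition as the group there shrinks. Compound 2, which also bears trifluoromethyl, returned only a limit. Compound 4 is therefore expected to move further up, the estimated step being a 1.6-fold higher number from compound 3 to compound 4 (0.20 log units; within the scatter). Compound 4 is estimated at 26000 nM, between 10000 nM and 60000 nM, with a real chance that this assay reports only a limit.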

Compound 4, half-maximal inhibitory concentration: 13100 nM
The estimate for compound 4 lay 2.0-fold (0.30 log units) above the measured number, and the stated range covers the measured number.
By their numbers in this assay, from the lowest: compounds 1, 4 and 3 (each within the scatter of the next, the first and the last beyond it). At a limit, above all of these: compound 2.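

In this assay, the exchange on the shared core gives a 1.2-fold lower number from compound 3 to compound 4 (0.09 log units; within the scatter), so methoxy and trifluoromethyl are not separated at this position, para to a large group. The comparison with the larger group gives a 1.9-fold higher number from compound 1 to compound 4 (0.28 log units; within the scatter), so (4-methyl-1,4-diazepan-1-yl)methyl is separated beyond the scatter from methoxy in compound 3 but not from trifluoromethyl in compound 4, and no clear advantage can be assigned to it. The core exchange with trifluoromethyl kept in place reads as an at least 1.5-fold lower number from compound 2 to compound 4 (0.18 log units; that floor lies within the scatter), which is only a floor, with compound 2 at a limit and not a number: the limit of > 20000 nM in this assay, at which 1 of the 4 values shown sits.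

From the compounds shown here alone, whether any group at this position gives much stronger inhibition than the three compared here remains open. A carboxylic acid, a primary amine or a longer chain ending in a piperazine could test this on the shared core.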